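The source may hold more compounds than are shown below. What is called first, only, known or untested is meant among the compounds shown, and "the series" means these compounds.

Measured compounds:
- compound 1 `Cc1c(C(=O)Nc2ccc(Oc3ncnc4[nH]cc(-c5ccccc5)c34)c(F)c2)c(=O)c2cc(F)ccc2n1C`: > 10000 nM
- compound 2 `Cc1ccc2[nH]c(C)c(C(=O)Nc3ccc(Oc4ncnc5[nH]cc(-c6ccccc6)c45)c(F)c3)c(=O)c2c1`: 560 nM

Of the compounds shown here, two sharing one core have been tested in an assay on isolated protein for inhibition of tyrosine-protein kinase receptor UFO (Homo sapiens), read by FRET and Z'-LYTE, with a stated time of 1.5 h; on this read-out higher numbers stand for weaker inhibition and lower numbers for stronger inhibition. Compound 1 returns only a limit of the assay, > 10000 nM, so it supplies no number. Among the measured compounds shown here, compound 2, by contrast, gives 560 nM in this assay, and this is the only real number in the set, so it stands alone as the reference point. Compound 1 sits at the limit described by the limit of > 10000 nM in this assay, at which 1 of the 2 values shown sits. For the measured compounds named here, no pair of measured compounds differs in a single place, so no measured step can be reported.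

Compound 3 `Cc1ccc2c(c1)c(=O)c(C(=O)Nc1ccc(Oc3ncnc4[nH]cc(-c5ccccc5)c34)c(F)c1)c(C)n2-c1ccccc1` is the next compound to be measured in this assay. It differs from compound 2 by phenyl in place of hydrogen on an aromatic nitrogen. Going by the values given here, with no measured step to lean on, the account can only note that compound 2 gives 560 nM. Compound 1, which carries a group on that same nitrogen among other changes, sits at its limit. On that basis the step is expected to run toward weaker inhibition, and to be larger than the usual scatter: the estimated step is a 5.4-fold higher number from compound 2 to compound 3 (0.73 log units; beyond the scatter). Compound 3 is accordingly estimated at 3000 nM, within a range from 500 nM to 20000 nM.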

Compound 3, half-maximal inhibitory concentration: 620 nM
Compound 3: middle estimate off by 4.8-fold (0.68 log units), on the high side; measured number inside the range.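

Phenyl in place of hydrogen on the aromatic nitrogen gives a 1.1-fold higher number from compound 2 to compound 3 (0.04 log units; within the scatter) in this assay, so this position carries a six-membered aromatic ring of carbon only with no change that can be read. Among the compounds shown here, this is the first measured step in the set, and it shows that a group on that nitrogen does not by itself go with weak inhibition, at least where the group is phenyl and the rest of the molecule is that of compound 2. Compound 1 also carries a group on that nitrogen, but it differs from compound 3 in more than one place, and its reading is a limit of the assay, not a number: the limit of > 10000 nM in this assay, at which 1 of the 3 values shown sits.

The compounds shown leave open whether the limit reading of compound 1 goes with the methyl on its aromatic nitrogen or with the fluorine it carries in place of the ring methyl of compound 3. For the compounds shown here, they also leave open how that nitrogen would take a chain ending in an amine or a carboxylic acid, since phenyl is the only group there that gives a number.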